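This account rests on a few compounds, and the source may have more. Where it says the series, first, only, none or still open, it means among the compounds named here.

Measured so far in an ADME assay on MDCK cells (Canis lupus familiaris) for cytotoxicity, read by microscopy, with a stated time of 48 h; a higher number here means that more compound is tolerated, a lower number that less compound is tolerated:
compound 1 `C[C@H]1[C@H](NCc2cncs2)C[C@H]2C[C@@H]1C2(C)C` gives > 100000 nM, a limit of the assay.
compound 2 `C[C@H]1[C@H](NCc2cnccn2)C[C@H]2C[C@@H]1C2(C)C` gives > 100000 nM, also a limit.
compound 3 `C[C@H]1[C@H](NCc2ccco2)C[C@H]2C[C@@H]1C2(C)C` gives 50000 nM.

For the measured compounds named here, compound 3 thus holds the only actual number; the other two values sit at the limit of > 100000 nM in this assay, at which 2 of the 3 values shown sit. The step to compound 4 `Cc1ccsc1CN[C@@H]1C[C@H]2C[C@@H]([C@H]1C)C2(C)C` is 3-methylthiophen-2-yl in place of furan-2-yl on a saturated chain carbon bound to an amine nitrogen. Going by the values given here, two measured steps touch the same place: an at least 2.0-fold lower number from compound 1 to compound 3 (0.30 log units; that floor lies within the scatter) and an at least 2.0-fold lower number from compound 2 to compound 3 (0.30 log units; that floor lies within the scatter), both floors lying within the scatter, while a step that the two limits leave unreadable from compound 1 to compound 2. Only the furan-bearing compound 3 gave a readable number; the two other aromatic groups stayed at the limit. For compound 4 a step of a 1.4-fold higher number from compound 3 to compound 4 (0.15 log units; within the scatter) is therefore expected, with a fair chance the assay again reports only a limit. Compound 4 is estimated at 70000 nM, ranging from 25000 nM to 200000 nM.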

Compound 4, minimum cytotoxic concentration: 10000 nM
Estimate against measurement, compound 4: 7.0-fold (0.85 log units) above; measured number outside the range, below it.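

In this assay, replacing furan-2-yl with 3-methylthiophen-2-yl gives a 5.0-fold lower number from compound 3 to compound 4 (0.70 log units; beyond the scatter), so the group on a saturated chain carbon bound to an amine nitrogen can shift the read-out by more than the scatter, which the earlier floors could not show. Against the other two aromatic groups, the change gives an at least 10-fold lower number from compound 2 to compound 4 (1.00 log units; beyond the scatter) and an at least 10-fold lower number from compound 1 to compound 4 (1.00 log units; beyond the scatter), both floors only: the limit of > 100000 nM in this assay, at which 2 of the 4 values shown sit.

Compound 4 is the least tolerated of the four. On these data alone, it stays open how a plain thiophen-2-yl or a phenyl group would read at this place, and so whether the methyl group or the sulfur carries the step.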